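A few compounds are considered here, and "the series" means these few. Any claim that something is new, unique, unknown or untested is made for them only; others in the source may bear on it.

Three close relatives were tested in a functional assay on NCI-H322M cells (Homo sapiens) for cytotoxicity, read by sulforhodamine B assay, with a stated time of 48 h; a lower number here means a stronger inhibitor of growth, a higher number a weaker inhibitor of growth. Compound 1 `ClCc1ccccc1Cn1cnc2c(Cl)nc(Cl)nc21` gives 1730 nM in this assay. Compound 2 `ClCc1ccccc1Cn1cnc2c(Cl)ncnc21` gives 3980 nM in this assay. Compound 3 `ClCc1cccc(Cn2cnc3c(Cl)ncnc32)c1` gives 1900 nM in this assay.

Compound 1 and compound 2 differ in one place: chloro in place of hydrogen on an aromatic carbon. That single change gave a 2.3-fold lower number from compound 2 to compound 1 (0.36 log units; beyond the scatter), so in this pair adding the chloro group made the growth inhibitor somewhat stronger.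

Compound 3 and compound 2 share the same atoms but joined differently; the difference between the two cores is not broken down here. Their values show that compound 3 gives the lower number of the two, by an amount that lies beyond the usual scatter, while compound 3 and compound 1 sit within the scatter of each other, so no order can be read between those two.

The unmeasured compound 4 `ClCc1cccc(Cn2cnc3c(Cl)nc(Cl)nc32)c1` relates to compound 3 exactly as compound 1 relates to compound 2: chloro in place of hydrogen on an aromatic carbon. The place of the change reads the same word for word in both pairs, so this is the same change, made on the other core.

If the change carries over, compound 4 is expected to be a 1.9-fold lower number from compound 3 to compound 4 (0.28 log units; within the scatter) relative to compound 3, resting on the single earlier step, because a 2.3-fold lower number from compound 2 to compound 1 (0.36 log units; beyond the scatter) pointed that way. One step on one pair is thin ground, so the expected value for compound 4 is placed at 1000 nM, with a likely range from 500 nM to 2100 nM.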

Compound 4, concentration for 50% growth inhibition: 2290 nM
Estimate against measurement, compound 4: 2.3-fold (0.36 log units) below; the measured number lies above the stated range.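

On the core of compound 3, placing a chloro group on the aromatic carbon between two ring nitrogen atoms gave a 1.2-fold higher number from compound 3 to compound 4 (0.08 log units; within the scatter) in this assay, so compound 3 and compound 4 cannot be told apart in this test, and the gain in growth inhibition seen with the same change on the other core does not appear here. The two results therefore disagree, and the change cannot simply be carried from one core to the other in this series: the same change on two cores in this assay, a 2.3-fold lower number (0.36 log units; beyond the scatter) from compound 2 to compound 1 and a 1.2-fold higher number (0.08 log units; within the scatter) from compound 3 to compound 4, 2.8-fold (0.44 log units) apart, beyond the scatter of two such steps. Among these compounds, this shows that the effect of the chloro group depends on the core it is placed on, at least across these two pairs, but it does not show why the cores differ, and with only two pairs in a single cell line it gives no general rule.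

The compounds shown leave open what other groups would do at this same aromatic carbon, for example an amine or a methyl group, and whether either would give the same result on both cores. They also leave open whether the disagreement between the two cores would appear in other cell lines.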